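Furan-3-yl in Place of Cyclopentylmethyl on the Amide Carbonyl

The source may report more compounds than this note shows. Statements on the series, on what has been measured and on what is new or still open speak of the compounds shown alone.

Going by the values given here, compound 2 `CCCC(=O)N1CCC(NS(=O)(=O)c2ccc(NC(=O)CC3CCCC3)c3ccccc23)CC1` gives 145 nM in an in vitro functional assay on CHO/Galpha16 cells for antagonist activity at C-C chemokine receptor type 8 (Homo sapiens), read by FLIPR (a lower number here means a stronger inhibitor, a higher number a weaker inhibitor), the highest of the two numbers measured so far, while compound 1 `CCCC(=O)N1CCC(NS(=O)(=O)c2ccc(NC(=O)c3ccccc3)c3ccccc23)CC1` gives 12.5 nM. Among the compounds with values here, the only measured step, a 12-fold higher number from compound 1 to compound 2 (1.06 log units; beyond the scatter), shows how strongly the group on this carbonyl carbon moves the read-out. Compound 3 `CCCC(=O)N1CCC(NS(=O)(=O)c2ccc(NC(=O)c3ccoc3)c3ccccc23)CC1` differs from compound 2 by furan-3-yl in place of cyclopentylmethyl on a carbonyl carbon. Because compound 1 gives 12.5 nM with an aromatic phenyl on that carbonyl, compound 3 is expected to fall well below compound 2, though not necessarily the whole way. Compound 3 is therefore estimated at 25 nM, between 8 nM and 80 nM, a step of a 5.8-fold lower number from compound 2 to compound 3 (0.76 log units; beyond the scatter).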

Compound 3, half-maximal inhibitory concentration: 1520 nM
Compound 3: the middle estimate sits 61-fold (1.78 log units) below what was measured; measured number above the stated range.
By their numbers in this assay, from the lowest: compound 1; then compound 2; then compound 3.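

Both a 10-fold higher number from compound 2 to compound 3 (1.02 log units; beyond the scatter) and a 120-fold higher number from compound 1 to compound 3 (2.08 log units; beyond the scatter) arise when furan-3-yl enters on this carbonyl carbon, so in this assay an aromatic ring there does not by itself give a low number. Compound 2, with non-aromatic cyclopentylmethyl, ranks between the aromatic compound 1 and compound 3, so aromaticity alone does not set the order of these three compounds. The compounds shown leave open whether thiophen-3-yl or pyridin-3-yl on this carbonyl carbon would track phenyl or furan-3-yl. No available evidence explains the gap between furan-3-yl and phenyl.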